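Working notes on lipophilicity across three related analogues

The source may report more compounds than this note shows. Statements on the series, on what has been measured and on what is new or still open speak of the compounds shown alone.

Compound 1 `C[C@H]1CC[C@@H]2[C@@H](OC(=O)[C@]23CC(c2cccc([N+](=O)[O-])c2)=NO3)[C@]2(C)C(=O)C=C[C@@]12O` gives 1.37 in a physicochemical assay for lipophilicity; a lower number here means a more polar compound, a higher number a more lipophilic compound.
Compound 2 `C[C@H]1CC[C@@H]2[C@@H](OC(=O)[C@]23CC(c2ccc(Br)cc2)N(c2ccccc2)O3)[C@]2(C)C(=O)C=C[C@@]12O` gives 4 in this assay.

Compound 2 stands highest of the two numbers in this assay; compound 1 sits lower by a margin beyond the usual scatter. Compound 3 `C[C@H]1CC[C@@H]2[C@@H](OC(=O)[C@]23CC(c2ccccc2Cl)N(c2ccccc2)O3)[C@]2(C)C(=O)C=C[C@@]12O` differs from compound 2 in one place: 2-chlorophenyl in place of 4-bromophenyl on a saturated ring carbon. Among the compounds with values here, no step between measured compounds covers such a change, so the expectation rests on compound 2 alone, anchored on its 4. For compound 3 the step of a number 0.20 log units lower from compound 2 to compound 3 (within the scatter) is expected to be small, downward if anything, and not beyond the scatter. Compound 3 is therefore estimated at 3.8, within 3.3 to 4.3.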

Compound 3, partition coefficient: 3.87
The estimate for compound 3 lay 0.07 log units below the measured number; low and high end bracket the measured number.
By their numbers in this assay, from the lowest: compound 1; then compounds 3 and 2 (each within the scatter of the next).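

Putting 2-chlorophenyl in place of 4-bromophenyl on the saturated ring carbon gives a number 0.13 log units lower from compound 2 to compound 3 (within the scatter) in this assay. Within the data shown here, this is the first step read at this position, and it shows that these two halogen-bearing phenyl groups cannot be told apart in this read-out. Nothing on hand speaks to why the step has this size.

The step changes both the halogen and its place on the phenyl ring, so the two changes cannot be separated. Going by these compounds, whether an amine or a carboxylic acid on this phenyl ring would move the number beyond the scatter remains open.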